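Trimming the ketone aryl group in a chalcone series

The compounds below may be only part of what the source reports. "The series", "measured", "known", "first", "only" and "open" are said of these compounds alone.

Of the compounds shown here, three have been measured in an in vitro ADME assay on microsomes from liver (Mus musculus) for metabolic stability, read by LC-MS, using NADPH, tested at 1 uM, in the presence of a further agent that is not named here; a higher number here means that the compound lasts longer, a lower number that the compound disappears faster. Compound 1 `COc1ccc(C(=O)/C=C/c2ccc(OCCNc3ccnc4cc(Cl)ccc34)c(OC)c2)c(OC)c1` gives 0.212 h, the second highest of the three numbers. Compound 2 `COc1ccc(C(=O)/C=C/c2ccc(O)c(CN3CCN(c4ccnc5cc(Cl)ccc45)CC3)c2)c(OC)c1` gives 0.757 h, a higher number that lies beyond the scatter. Compound 3 `COc1cc(/C=C/C(C)=O)ccc1OCc1cn(-c2ccnc3cc(Cl)ccc23)nn1` gives 0.103 h, a lower number that also lies beyond the scatter. Compound 4 `COc1cc(/C=C/C(C)=O)ccc1OCCNc1ccnc2cc(Cl)ccc12` has not yet been measured; it differs from compound 1 by methyl in place of 2,4-dimethoxyphenyl on a carbonyl carbon. Among the measured compounds shown here, no step between two measured compounds isolates this change, but compound 3, which also carries a methyl on the carbonyl carbon, gives 0.103 h, so a modest drop is expected. The step from compound 1 to compound 4 is estimated at a 1.4-fold lower number from compound 1 to compound 4 (0.15 log units; within the scatter), and compound 4 is expected to give 0.15 h, between 0.06 h and 0.4 h.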

Compound 4, half-life in the liver assay: 0.223 h
For compound 4 the middle estimate is 1.5-fold (0.17 log units) below the measured one, and the stated range covers the measured number.
By their numbers in the liver assay, from the lowest: compound 3; then compounds 1 and 4 (each within the scatter of the next); then compound 2.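

Among the compounds shown here, in the liver assay the first direct reading at this position, methyl in place of 2,4-dimethoxyphenyl on a carbonyl carbon, is a 1.1-fold higher number from compound 1 to compound 4 (0.02 log units; within the scatter), so the whole aryl group can be exchanged without a difference beyond the scatter. In a physicochemical assay for solubility, at pH 2 (on this read-out lower numbers stand for lower solubility and higher numbers for higher solubility), the same change reads an at least 2.0-fold lower number from compound 1 to compound 4 (0.30 log units; that floor lies within the scatter), with compound 4 at 50 ug/mL. In the physicochemical assay compound 1 gives > 100 ug/mL, which is a limit of the assay and not a number: the limit of > 100 ug/mL in the physicochemical assay, at which 1 of the 2 values shown sits.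

As far as these compounds go, how far the step in the physicochemical assay truly reaches stays open. So does how other groups on this carbonyl carbon, such as ethyl, phenyl or an amine, would read in the liver assay.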